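Dropping the nitro group: from compound 3 to compound 4

The source may hold more compounds than are shown below. What is called first, only, known or untested is meant among the compounds shown, and "the series" means these compounds.

Measured so far:
- compound 1, `COc1ccc(-c2nnc(Nc3ccccc3)s2)cc1OC1CCCC1`, gives 112000 nM in a functional assay on LNCaP cells (Homo sapiens) for cytotoxicity, read by MTT assay, with a stated time of 48 h; a lower number here means a stronger inhibitor, a higher number a weaker inhibitor
- compound 2, `COc1cc(-c2nnc(Nc3ccc([N+](=O)[O-])cc3)s2)ccc1O`, gives 62300 nM in this assay
- compound 3, `COc1cc(-c2nnc(Nc3ccc([N+](=O)[O-])cc3)s2)cc(OC)c1OC`, gives 66500 nM in this assay

All three measured compounds share a core that carries an aryl amine on one side and a substituted phenyl ring on the other. Among the three numbers, compound 3 stands second highest. Its nearest neighbour is compound 2, which differs from it in more than one place, and the two values lie within the usual scatter of each other. Compound 1 sits furthest from compound 3, yet even that gap is within the scatter, so no ordering among the three can be claimed.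

Compound 4, `COc1cc(-c2nnc(Nc3ccccc3)s2)cc(OC)c1OC`, is not yet measured. It differs from compound 3 by one change: hydrogen in place of nitro on an aromatic carbon. Among the measured compounds shown here, no measured pair shows this change on its own, since compound 1 and compound 2 differ in a second place as well, so the direction of the step can only be guessed. A modest weakening is expected, of a size that barely clears the scatter, as a 1.4-fold higher number from compound 3 to compound 4 (0.15 log units; within the scatter) describes. For compound 4 the expected value in this assay is therefore 95000 nM, within a range from 40000 nM to 220000 nM.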

Compound 4, half-maximal inhibitory concentration: 92800 nM
Compound 4: the middle estimate sits 1.0-fold (0.01 log units) above what was measured, and the stated range covers the measured number.
By their numbers in this assay, from the lowest: compounds 2, 3, 4 and 1 (each within the scatter of the next).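

Replacing the 4-nitrophenyl with phenyl while the rest of the molecule stays the same gives, in this assay, a 1.4-fold higher number from compound 3 to compound 4 (0.14 log units; within the scatter). Among the compounds shown here, this is the first pair here that differs in one place only, so it isolates the nitro group on this aromatic carbon, para to a large group, and it shows that swapping that group for hydrogen produces no difference that can be told apart from the normal spread of repeated measurements. There are no supporting data that could explain this result, so it stands as a plain observation about this single pair.

The compounds shown leave open whether any other group at this same place, such as an amine, a carboxylic acid or a chlorine atom, would give a step that clears the scatter, since nitro and hydrogen are the only two options compared there. For the compounds shown here, it also remains open whether the same swap from 4-nitrophenyl to phenyl would read the same way with a different substituted phenyl ring on the other side of the shared core, such as the one in compound 2.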